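Lengthening the acid arm on the pyrrolidine of compound 2

The compounds below may be only part of what the source reports. "The series", "measured", "known", "first", "only" and "open" are said of these compounds alone.

Compound 2 `O=C(O)C1CCN(c2ccc(OCc3ccc(Cl)cc3Cl)cc2)C1` gives only a limit, > 16000 nM, in a functional assay on cells for agonist activity at Free fatty acid receptor 1 (Mus musculus), read by FLIPR and calcium flux, with a stated time of 100 s; a higher number here means that more compound is needed for the effect, a lower number that less compound is needed; that limit is where it stands. Compound 1 `O=C(O)C1CC(=O)N(c2ccc(OCc3ccc(Cl)cc3Cl)cc2)C1` likewise gives only a limit, > 33000 nM, in this assay. Both shown values are limits, so no measured step exists. Compound 3 `O=C(O)CC1CCN(c2ccc(OCc3ccc(Cl)cc3Cl)cc2)C1` differs from compound 2 by carboxymethyl in place of carboxy on a saturated ring carbon. For the measured compounds named here, with no measured step to lean on, a gain within or modestly beyond the scatter is expected, with the step from compound 2 expected as an at least 1.6-fold lower number from compound 2 to compound 3 (0.20 log units; that floor lies within the scatter). Compound 3 is therefore estimated at 10000 nM, between 2000 nM and 50000 nM.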

Compound 3, half-maximal effective concentration: > 33000 nM
Compound 3 was reported as a limit (the forecaster's own chance of this, stated with the estimate: 50%); middle value at least 3.3-fold (0.51 log units) away from the limit.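

Compound 2 and compound 3 both give only limits in this assay, and the step between them cannot be read. The compounds shown leave open whether carboxymethyl in place of carboxy changes the required concentration at all.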